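The source may hold more compounds than are shown below. What is called first, only, known or untested is meant among the compounds shown, and "the series" means these compounds.

Compound 1 `O=C1OC(c2ccc(F)cc2)C(c2ccc(O)cc2)=C1O` is the point of departure for this piece; in an assay on blood for inhibition of Polyunsaturated fatty acid 5-lipoxygenase (Homo sapiens), tested at 100 uM (a higher number here means a stronger effect of the compound at the concentration tested, a lower number a weaker effect), compound 1 gives 16.4%. Only one other compound of the set has a number in this assay: compound 3 `O=C1OC(c2cc(O)cc(O)c2)C(c2ccc(O)cc2)=C1O`, which gives 11.6%, and the two numbers sit within the usual scatter of each other, so on the numbers shown compound 1 cannot be told apart from compound 3. Compound 2 `O=C1OC(c2ccc(OCc3ccccc3)c(OCc3ccccc3)c2)C(c2ccc(F)cc2)=C1O` was also part of the study, but in this assay compound 2 stands as "not determined" (no result reported), so no result was reported for it. Compound 4 `O=C1OC(c2ccc(O)cc2)C(c2ccc(O)cc2)=C1O` has not yet been measured.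

The step from compound 1 to compound 4 is a single exchange: hydroxy in place of fluoro on an aromatic carbon. Among the measured compounds shown here, no pair of measured compounds differs in just this one place, so the size of this step in this assay cannot be read off from any measured pair. Given that compound 1 and compound 3, which both carry hydroxy groups on their rings, lie within the scatter of each other, the expectation is for no step beyond the scatter, in either direction. The expected step from compound 1 to compound 4 is a number 2.4 percentage points lower from compound 1 to compound 4 (within the scatter). Compound 4 is therefore estimated to give 14% in this assay, with a likely range from 4% to 26%.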

Compound 4, a percentage reported as activity, at one concentration (the size of the read-out at that concentration, not a potency): 27.8%
For compound 4 the middle estimate is 13.8 percentage points below the measured one, outside the stated range (above it).
By their numbers in this assay, from the lowest: compounds 3 and 1 (each within the scatter of the next); then compound 4.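

In this assay, among the compounds shown here, the exchange on an aromatic carbon para to a large group gives the first step in this set that can be read directly: a number 11.4 percentage points higher from compound 1 to compound 4 (beyond the scatter) is a modest change, but it is larger than the usual scatter. This shows that the position is not indifferent to what sits on it, since replacing one heavy atom, fluorine, with another, oxygen, is enough to change the read-out, and the exchange also adds one hydrogen-bond donor and one hydrogen-bond acceptor to the count. Nothing measured here shows what lies behind this step.

This is also a single pair at a single concentration, so it gives no potency and cannot show whether the same exchange would have a similar effect if the rest of the molecule were different. Going by these compounds, it also remains open how an amine, a methoxy group or a carboxylic acid at this position would compare with hydroxy and fluoro, and whether any of them would raise or lower the read-out.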